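This account rests on a few compounds, and the source may have more. Where it says the series, first, only, none or still open, it means among the compounds named here.

Compound 1 `Cc1ccc(-c2ccc(C(=O)Nc3ccc(Oc4ccnc5[nH]ccc45)cc3)nc2)cc1`: > 10000 nM
Compound 2 `Cc1ccc(-c2ccc(C(=O)Nc3ccc(Oc4ccnc5[nH]ccc45)c(F)c3)nc2)cc1`: 8020 nM

These results come from a functional assay on MCF7 cells (Homo sapiens) for cytotoxicity, read by MTT assay, with a stated time of 72 h; a higher number here means a weaker inhibitor, a lower number a stronger inhibitor. Compound 1 gives > 10000 nM, which is a limit of the assay and not a number. Among the measured compounds shown here, compound 2 gives 8020 nM, the only true number so far. Compound 3 `O=C(Nc1ccc(Oc2ccnc3[nH]ccc23)c(F)c1)c1ccc(-c2ccc(F)cc2F)cn1` carries 2,4-difluorophenyl in place of the 4-methylphenyl of compound 2: 2,4-difluorophenyl in place of 4-methylphenyl on an aromatic carbon.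

For the measured compounds named here, the one measured step, an at least 1.2-fold lower number from compound 1 to compound 2 (0.09 log units; that floor lies within the scatter), placed fluoro on an aromatic carbon and left this group untouched. Its floor lies within the scatter. Going by the values given here, no measured step exchanges this group, so the data offer no direction for the change. No step beyond the scatter is therefore expected in this assay. The estimate amounts to a 1.1-fold lower number from compound 2 to compound 3 (0.06 log units; within the scatter), an expected step within the scatter. For compound 3 the estimated value is 7000 nM, with an expected range from 2500 nM to 10000 nM.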

Compound 3, half-maximal inhibitory concentration: > 10000 nM
Compound 3 was reported as a limit; the forecaster's own chance of this, stated with the estimate: 35%; middle value at least 1.4-fold (0.15 log units) away from the limit.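

In this assay, among the compounds shown here, this is the first measured exchange of the group on the aromatic carbon two atoms from the ring nitrogen, and it gives an at least 1.2-fold higher number from compound 2 to compound 3 (0.09 log units; that floor lies within the scatter). Compound 3 gives > 10000 nM, which is a limit of the assay and not a number. The change from 4-methylphenyl to 2,4-difluorophenyl therefore brings no measurable gain over compound 2, and how much is lost, if anything, cannot be read: the limit of > 10000 nM in this assay, at which 2 of the 3 values shown sit.

From the compounds shown here alone, both groups tested at this position are substituted phenyl groups, so it remains open whether an amine or a carboxylic acid there would give a clearly lower number. Going by these compounds, it also remains open whether the aromatic fluoro that separates compound 2 from compound 1 would change the number when 2,4-difluorophenyl is present.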